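From pyridin-3-yl to 5-aminopyridin-3-yl

This account rests on a few compounds, and the source may have more. Where it says the series, first, only, none or still open, it means among the compounds named here.

In a functional assay on COR-L23 cells (Homo sapiens) for antiproliferative activity, read by CellTiter-Glo, with a stated time of 72 h (a higher number here means a weaker inhibitor, a lower number a stronger inhibitor), compound 2 `C[C@H](NC(=O)[C@@H]1CCCN1C)c1ccc(NC(=O)N2CC(c3cccnc3)C2)cc1` gives 38 nM and compound 1 `C[C@H](NC(=O)C1CCOCC1)c1ccc(NC(=O)N2CC(c3cccnc3)C2)cc1` gives 58 nM, which places the two within the scatter of each other. Among the compounds with values here, the only measured step, a 1.5-fold lower number from compound 1 to compound 2 (0.18 log units; within the scatter), concerns a group on a carbonyl carbon and not the pyridin-3-yl. Compound 3 `C[C@H](NC(=O)[C@@H]1CCCN1C)c1ccc(NC(=O)N2CC(c3cncc(N)c3)C2)cc1` carries amino in place of hydrogen on an aromatic carbon, (amino in place of hydrogen on an aromatic carbon), turning pyridin-3-yl into 5-aminopyridin-3-yl. Within the data shown here, no measured step tests this change, so no shift beyond the scatter is expected in this assay. The expected step is a 1.6-fold higher number from compound 2 to compound 3 (0.20 log units; within the scatter). Compound 3 is estimated at 60 nM, within an expected range of 15 nM to 250 nM.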

Compound 3, half-maximal inhibitory concentration: 200 nM
The estimate for compound 3 lay 3.3-fold (0.52 log units) below the measured number, within the range that was stated.
By their numbers in this assay, from the lowest: compounds 2 and 1 (each within the scatter of the next); then compound 3.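

Up to this point the only measured step lay on the carbonyl side and stayed within the scatter. Amino in place of hydrogen on the pyridin-3-yl gives the first step beyond the scatter in this assay, a 5.3-fold higher number from compound 2 to compound 3 (0.72 log units; beyond the scatter), so this ring position is not indifferent to substitution. Nothing at hand accounts for this shift. On these data alone, whether another group at this place, such as hydroxyl, methoxy or fluorine, would shift the number as amino does stays open. So does whether the same change would cost as much with oxan-4-yl on the carbonyl carbon.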